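A few compounds are considered here, and "the series" means these few. Any claim that something is new, unique, unknown or untested is made for them only; others in the source may bear on it.

Compound 1, `Nc1nc(O)c2ncn([C@H]3O[C@@H](CO)C=C3F)c2n1`. In a functional assay on Vero cells (Chlorocebus sabaeus) for inhibition (a lower number here means a stronger inhibitor, a higher number a weaker inhibitor), compound 1 gives only a limit, > 100000 nM.
Compound 2, `OC[C@H]1C=C(F)[C@@H](n2cnc3c(O)ncnc32)O1`. In this assay compound 2 likewise gives only a limit, > 100000 nM.

Compound 1 thus stands at the limit of this assay, with no number of its own. Compound 2 differs from it by hydrogen in place of amino on an aromatic carbon, and that change gives a step that the two limits leave unreadable from compound 1 to compound 2 because both compounds sit at the limit of > 100000 nM in this assay, at which 2 of the 2 values shown sit. Compound 3, `Nc1nc(O)c2ncn([C@@H]3O[C@@H](CO)C=C3F)c2n1`, differs from compound 1 as follows: the two compounds have the same atoms and bonds and differ only in configuration as drawn: 1 of 2 stereo elements differ; a stereocentre at a saturated ring carbon is drawn S in compound 1 and R in compound 3. For the measured compounds named here, no measured step involves a change of configuration, and the one step that was measured cannot be read, so there is nothing to show how large a change in this assay to expect, or in which direction. With the starting point itself a limit, compound 3 is estimated at 100000 nM, within 10000 nM to 400000 nM, and is expected most likely to return only a limit again. The expected step is a number no higher from compound 1 to compound 3 (the limit leaves the size open).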

Compound 3, half-maximal inhibitory concentration: > 100000 nM
Compound 3: no number, only a limit; the forecaster's own chance of this, stated with the estimate: 70%; the middle value sits exactly at the limit.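

Compound 3 gives only a limit in this assay, so the step from compound 1 cannot be read, because both compounds sit at the same limit: the limit of > 100000 nM in this assay, at which 3 of the 3 values shown sit.

The compounds shown leave open whether swapping amino for hydrogen, or changing the configuration at the saturated ring carbon, alters inhibition at all: none of them gives a number.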